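A few compounds are considered here, and "the series" means these few. Any claim that something is new, unique, unknown or untested is made for them only; others in the source may bear on it.

Compound 1 `CCN(CC)Cc1ccc2nc(NC(=O)N/N=C/c3c[nH]c4ccccc34)sc2c1` gives 3300 nM in a functional assay on A549 cells (Homo sapiens) for cytotoxicity, read by MTT assay, with a stated time of 72 h (on this read-out lower numbers stand for stronger inhibition and higher numbers for weaker inhibition), level with compound 3 `CN(C)Cc1ccc2nc(NC(=O)N/N=C/c3c[nH]c4ccccc34)sc2c1`, which gives 3300 nM, and together they hold the highest number of the three measured compounds, though compound 2 `CC1CCN(Cc2ccc3nc(NC(=O)N/N=C4\C(=O)Nc5ccc(F)cc54)sc3c2)CC1`, which gives 3010 nM, sits within the scatter of both. Compound 4 `CCN(CC)Cc1ccc2nc(NC(=O)N/N=C/c3cn(Cc4ccccc4)c4ccccc34)sc2c1` is built from compound 1 by benzyl in place of hydrogen on an aromatic nitrogen. Within the data shown here, the only measured step, no change at the digits printed from compound 1 to compound 3 (within the scatter), concerns the amine on the other end of the shared core and does not touch the aromatic nitrogen, so no recorded step bears directly on this change. With nothing to point either way, compound 4 is expected to stay close to compound 1, a step of a 1.1-fold lower number from compound 1 to compound 4 (0.04 log units; within the scatter), and its estimated value is 3000 nM, within a range from 1000 nM to 10000 nM.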

Compound 4, half-maximal inhibitory concentration: 3330 nM
Estimate against measurement, compound 4: 1.1-fold (0.05 log units) below, and the stated range covers the measured number.
By their numbers in this assay, from the lowest: compounds 2, 1, 3 and 4 (each within the scatter of the next).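

In this assay, the step for benzyl in place of hydrogen on an aromatic nitrogen reads a 1.0-fold higher number from compound 1 to compound 4 (0.00 log units; within the scatter), within the scatter. The earlier step concerned only the amine at the other end of the shared core, whereas this one shows that, with diethylamino in place, this nitrogen can carry benzyl and its six-membered aromatic ring without a step beyond the scatter. From the compounds shown here alone, whether an acetyl group on this nitrogen or a carboxylic acid on the benzyl ring would leave the number level stays open. No measurement offered here accounts for this result.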